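The compounds below may be only part of what the source reports. "The series", "measured", "known", "first", "only" and "open" are said of these compounds alone.

Measured so far in a functional assay (Pituitary gland cell) with Rattus norvegicus as the target; a higher number here means that more compound is needed for the effect, a lower number that less compound is needed:
- compound 1 `CCOC(=O)CNC(C)(C)CC(=O)N[C@@H]1CCc2ccccc2N(Cc2ccc(-c3ccccc3-c3nn[nH]n3)cc2)C1=O`: 56 nM
- compound 2 `CC(C)(O)CNC(C)(C)CC(=O)N[C@@H]1CCc2ccccc2N(Cc2ccc(-c3ccccc3-c3nn[nH]n3)cc2)C1=O`: 10 nM
- compound 3 `CC(C)[C@@H](O)CNC(C)(C)CC(=O)N[C@@H]1CCc2ccccc2N(Cc2ccc(-c3ccccc3-c3nn[nH]n3)cc2)C1=O`: 200 nM

Compound 3 has the highest number of the three, with a 3.6-fold higher number from compound 1 to compound 3 (0.55 log units; beyond the scatter) and a 20-fold higher number from compound 2 to compound 3 (1.30 log units; beyond the scatter). The next compound is compound 4 `CC(C)(N)C(=O)N[C@@H]1CCc2ccccc2N(Cc2ccc(-c3ccccc3-c3nn[nH]n3)cc2)C1=O`, not yet measured. The change is 1-amino-1-methylethyl in place of 2-((2-hydroxy-3-methylbutyl)amino)-2-methylpropyl on a carbonyl carbon; in words, 1-amino-1-methylethyl in place of 2-((2-hydroxy-3-methylbutyl)amino)-2-methylpropyl on a carbonyl carbon.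

The measured steps bear on this only indirectly. Each exchanges one group on a saturated chain carbon bound to an amine nitrogen, and none replaces the whole side chain as this change does. They do show that edits within that side chain move the number in both directions: a 5.6-fold lower number from compound 1 to compound 2 (0.75 log units; beyond the scatter) is modest, while a 20-fold higher number from compound 2 to compound 3 (1.30 log units; beyond the scatter) is large. For the measured compounds named here, a large move is therefore possible, but no measured step fixes its direction. A modest rise is expected as a working guess, with little support from the data. The expected step is a 2.5-fold higher number from compound 3 to compound 4 (0.40 log units; beyond the scatter). The estimate for compound 4 is 500 nM, with an expected range of 80 nM to 3000 nM.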

Compound 4, concentration for half-maximal effect: 30 nM
Estimate against measurement, compound 4: 17-fold (1.22 log units) above; measured number outside the range, below it.
By their numbers in this assay, from the lowest: compound 2; then compounds 4 and 1 (each within the scatter of the next); then compound 3.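

In this assay, the whole 2-((2-hydroxy-3-methylbutyl)amino)-2-methylpropyl group on a carbonyl carbon can give way to the much smaller 1-amino-1-methylethyl with no loss, and the number improves (a 6.7-fold lower number from compound 3 to compound 4 (0.82 log units; beyond the scatter)); the longer amine side chain of compound 3 is therefore not needed for activity in this series. The longer chains do not all behave alike against compound 4: the 2-hydroxy-2-methylpropyl version keeps an advantage (a 3.0-fold higher number from compound 2 to compound 4 (0.48 log units; beyond the scatter)), whereas the ethoxycarbonyl version cannot be told apart from the short group, its step lying within the scatter (a 1.9-fold lower number from compound 1 to compound 4 (0.27 log units; within the scatter)). No measurement shown here explains why the shortened group performs as it does.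

Going by these compounds, it remains open whether a plain methyl or a carboxylic acid carried on the chain at the amine nitrogen would match compound 2 or fall back towards compound 3. The compounds shown also leave unsettled whether a cyclic amine such as piperidine could stand in place of 1-amino-1-methylethyl on the same carbonyl carbon.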